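Notes on compound 4 in the cytotoxicity series

The compounds below may be only part of what the source reports. "The series", "measured", "known", "first", "only" and "open" are said of these compounds alone.

The series shares one core and varies only the aryl group attached on an aromatic carbon of the six-membered aromatic ring with one nitrogen. Compound 1 `Cc1ccc(-c2ccc(C(=O)Nc3ccc(Oc4ccnc5[nH]ccc45)cc3)nc2)cc1` carries a 4-methylphenyl group. In a functional assay on MCF7 cells (Homo sapiens) for cytotoxicity, read by MTT assay, with a stated time of 72 h (a higher number here means a weaker inhibitor, a lower number a stronger inhibitor), compound 1 gives > 10000 nM, which is a limit of the assay and not a number. Compound 2 `COc1ccc(-c2ccc(C(=O)Nc3ccc(Oc4ccnc5[nH]ccc45)cc3)nc2)cc1` carries a 4-methoxyphenyl group. In this assay compound 2 gives > 10000 nM, again a limit. Compound 3 `O=C(Nc1ccc(Oc2ccnc3[nH]ccc23)cc1)c1ccc(-c2ccc(F)cc2F)cn1` carries a 2,4-difluorophenyl group. In this assay compound 3 gives > 10000 nM, also a limit. Compound 3 therefore stands where every measured compound stands, namely at the limit of > 10000 nM in this assay, at which 3 of the 3 values shown sit. The steps a step that the two limits leave unreadable from compound 1 to compound 2, a step that the two limits leave unreadable from compound 1 to compound 3 and a step that the two limits leave unreadable from compound 2 to compound 3 are all unreadable in size and direction.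

Compound 4 `CCc1ccc(-c2ccc(C(=O)Nc3ccc(Oc4ccnc5[nH]ccc45)cc3)nc2)cc1` has not yet been measured. The change from compound 3 is 4-ethylphenyl in place of 2,4-difluorophenyl on an aromatic carbon. Within the data shown here, none of the measured steps gives a readable size, so no direction can be taken from them. Because all three measured values sit at the limit of > 10000 nM in this assay, at which 3 of the 3 values shown sit, compound 4 is expected to sit at the limit as well. The step implied by this estimate, a step that the limit leaves unreadable from compound 3 to compound 4, is expected to stay within the scatter. In this assay compound 4 is estimated at 15000 nM, with a range from 7000 nM to 50000 nM.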

Compound 4, half-maximal inhibitory concentration: > 10000 nM
Compound 4: only a limit was reported; the forecaster's own chance of this, stated with the estimate: 85%; the middle value lies beyond the limit too.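

In this assay, among these compounds, compound 4 gives > 10000 nM, a limit of the assay and not a number, so no step from compound 1, compound 2 or compound 3 to compound 4 can be read. The compounds shown leave open how any aryl group on the shared core changes cytotoxicity, with every value at one limit: the limit of > 10000 nM in this assay, at which 4 of the 4 values shown sit.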